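Swapping the Hydroxyethoxypyridine for a Pyrazole Ester

The source may hold more compounds than are shown below. What is called first, only, known or untested is meant among the compounds shown, and "the series" means these compounds.

Measured compounds:
compound 1 `CCCCS(=O)(=O)Nc1cc(-c2ccc3ncnc(Nc4ccc(OCCO)nc4)c3c2)cnc1OC`: > 20000 nM
compound 2 `COc1ncc(-c2ccc3ncnc(Nc4ccc(OCCO)nc4)c3c2)cc1NS(C)(=O)=O`: 3080 nM
compound 3 `COc1ncc(-c2ccc3ncnc(Nc4ccc(OCCO)nc4)c3c2)cc1NS(=O)(=O)c1ccc(F)cc1F`: 4300 nM

In a functional assay on MCF7 cells (Homo sapiens) for antiproliferative activity, read by sulforhodamine B assay, with a stated time of 72 h (on this read-out lower numbers stand for stronger inhibition and higher numbers for weaker inhibition), compound 2 gives 3080 nM, the lowest of the two numbers shown. Compound 3 sits nearest, with a 1.4-fold higher number from compound 2 to compound 3 (0.14 log units; within the scatter). For compound 1 the assay reports only a limit, (the limit of > 20000 nM in this assay, at which 1 of the 3 values shown sits). Compound 4 `COC(=O)CCn1cc(Nc2ncnc3ccc(-c4cnc(OC)c(NS(C)(=O)=O)c4)cc23)cn1` differs from compound 2 by 1-(2-(methoxycarbonyl)ethyl)-1H-pyrazol-4-yl in place of 6-(2-hydroxyethoxy)pyridin-3-yl on a nitrogen on an aromatic ring. Among the measured compounds shown here, none of the measured steps touches this part of the molecule: an at least 6.4-fold lower number from compound 1 to compound 2 (0.81 log units; beyond the scatter) and an at least 4.6-fold lower number from compound 1 to compound 3 (0.66 log units; beyond the scatter) both change the group on the sulfonyl sulfur, on the opposite side of the shared core. So no measured step bears on the step to compound 4, and the expectation rests on compound 2 alone, with wide uncertainty. Compound 4 is estimated at 2500 nM, within 500 nM to 12000 nM, which is expected to mean a 1.2-fold lower number from compound 2 to compound 4 (0.09 log units; within the scatter).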

Compound 4, half-maximal inhibitory concentration: 490 nM
Compound 4: the middle estimate sits 5.1-fold (0.71 log units) above what was measured; the whole stated range lies above it.
By their numbers in this assay, from the lowest: compound 4; then compounds 2 and 3 (each within the scatter of the next). At a limit, above all of these: compound 1.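

In this assay, the group on the nitrogen on an aromatic ring proves able to shift the number: 1-(2-(methoxycarbonyl)ethyl)-1H-pyrazol-4-yl in place of 6-(2-hydroxyethoxy)pyridin-3-yl gives a 6.3-fold lower number from compound 2 to compound 4 (0.80 log units; beyond the scatter) in a single swap. Among the compounds shown here, the earlier steps changed only the group on the sulfonyl sulfur, so this is the first measured change on this side of the molecule. Nothing measured here explains the step. Going by these compounds, the swap replaces ring and side chain together, so which of them carries the step stays open. Also open, on these data alone, is how a carboxylic acid or an amine in place of the methyl ester would behave.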